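The source may hold more compounds than are shown below. What is called first, only, known or untested is meant among the compounds shown, and "the series" means these compounds.

Measured so far in an ADME assay on HEK293 cells for agonist activity at metabotropic glutamate receptor 5 (Rattus norvegicus), read by fluorescence and calcium flux; a lower number here means a smaller maximal response, a higher number a larger maximal response:
Compound 1 `C[C@@H](NC(=O)c1ccc(C#Cc2ccc(F)cc2F)cn1)C(C)(C)O` gives 38.2%.
Compound 2 `Cc1cccc(C#Cc2ccc(C(=O)N[C@H](C)C(C)(C)O)nc2)c1` gives 20.8%.
Compound 3 `C[C@@H](NC(=O)c1ccc(C#Cc2cccnc2)cn1)C(C)(C)O` gives 25.9%.

Compound 3 stands second highest of these three numbers. Within the data shown here, its nearest neighbour is compound 2, the two lying within the scatter of each other, as the step of a number 5.1 percentage points higher from compound 2 to compound 3 (within the scatter) shows; the step of a number 12.3 percentage points lower from compound 1 to compound 3 (beyond the scatter) is the only one that sets compound 3 apart beyond the scatter. Compound 4 `C[C@@H](NC(=O)c1ccc(C#Cc2ncccc2F)cn1)C(C)(C)O` differs from compound 3 in one place: 3-fluoropyridin-2-yl in place of pyridin-3-yl on a triple-bonded carbon. Among the measured compounds shown here, the steps that bear on this change are those that swap the group on the triple-bonded carbon, a number 17.4 percentage points lower from compound 1 to compound 2 (beyond the scatter) and a number 12.3 percentage points lower from compound 1 to compound 3 (beyond the scatter), both modest, and a number 5.1 percentage points higher from compound 2 to compound 3 (within the scatter), within the scatter. A change in the same place is therefore expected to give at most a modest step in this assay, with no clear direction. Compound 4 is expected to give 28%, between 15% and 42%, an expected step of a number 2.1 percentage points higher from compound 3 to compound 4 (within the scatter).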

Compound 4, largest response reached (reported as efficacy), in percent of the reference or control that the assay uses: 29.2%
For compound 4 the middle estimate is 1.2 percentage points below the measured one; low and high end bracket the measured number.
By their numbers in this assay, from the lowest: compounds 2, 3, 4 and 1 (each within the scatter of the next, the first and the last beyond it).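

In this assay the 3-fluoropyridin-2-yl group on the triple-bonded carbon is the only group shown that lies within the scatter of all the others, as the steps of a number 3.3 percentage points higher from compound 3 to compound 4 (within the scatter) and a number 8.4 percentage points higher from compound 2 to compound 4 (within the scatter) and a number 9 percentage points lower from compound 1 to compound 4 (within the scatter) show. The pyridin-3-yl group, by contrast, stands apart from compound 1 in the step of a number 12.3 percentage points lower from compound 1 to compound 3 (beyond the scatter) and so a pyridine ring at this place does not always separate a compound from compound 1. Nothing available explains this result. Going by these compounds, whether an amine or a longer chain on the triple-bonded carbon would stay within this range remains open.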